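Series notes: from compound 3 to compound 4

The compounds below may be only part of what the source reports. "The series", "measured", "known", "first", "only" and "open" are said of these compounds alone.

Values in a functional assay on DU-145 cells (Homo sapiens) for inhibition, read by trypan blue exclusion, with a stated time of 72 h; on this read-out higher numbers stand for weaker inhibition and lower numbers for stronger inhibition:
compound 1 `COc1ccc(Nc2ncc3cc(S(=O)(=O)c4ccc(C)cc4)c(=O)n(C)c3n2)cc1` gives 100000 nM
compound 2 `Cc1ccc(S(=O)(=O)c2cc3cnc(Nc4cnc5c(c4)CC(=O)N5)nc3n(C)c2=O)cc1` gives 15000 nM
compound 3 `Cc1ccc(S(=O)(=O)c2cc3cnc(Nc4ccc5cc[nH]c5c4)nc3n(C)c2=O)cc1` gives 15000 nM

Compound 3 stands level with compound 2 at the digits shown, and the two together hold the lowest number of the three. Compound 1 sits apart, with a 6.7-fold lower number from compound 1 to compound 3 (0.82 log units; beyond the scatter) and a 6.7-fold lower number from compound 1 to compound 2 (0.82 log units; beyond the scatter).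

Compound 4 `Cc1ccc(S(=O)(=O)c2cc3cnc(Nc4cnc5[nH]ccc5c4)nc3n(C)c2=O)cc1` differs from compound 3 in one place: a group of 9 heavy atoms (7 carbon, 2 nitrogen; one five-membered aromatic ring with 1 hetero atom, one six-membered aromatic ring with 1 hetero atom) in place of a group of 9 heavy atoms (8 carbon, 1 nitrogen; one five-membered aromatic ring with 1 hetero atom, one six-membered aromatic ring of carbon only), on a nitrogen on an aromatic ring. The two steps from compound 1 replace 4-methoxyphenyl and are the larger ones, but they start from a different group. The closer precedent is no change at the digits printed from compound 2 to compound 3 (within the scatter). That step also sets a six-membered aromatic ring with 1 hetero atom against a six-membered aromatic ring of carbon only, though the five-membered ring changes with it. No step beyond the scatter is therefore expected in this assay. The estimated step is no change at the digits printed from compound 3 to compound 4 (within the scatter). For compound 4 the estimate is 15000 nM, with an expected range of 6000 nM to 40000 nM.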

Compound 4, half-maximal inhibitory concentration: 25000 nM
The estimate for compound 4 lay 1.7-fold (0.22 log units) below the measured number; low and high end bracket the measured number.
By their numbers in this assay, from the lowest: compounds 2, 3 and 4 (each within the scatter of the next); then compound 1.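

In this assay, a six-membered aromatic ring with 1 hetero atom in place of a six-membered aromatic ring of carbon only, with the five-membered aromatic ring kept, gives a 1.7-fold higher number from compound 3 to compound 4 (0.22 log units; within the scatter), so this exchange alone, which adds 1 hydrogen-bond acceptor and keeps the donor, does not separate the two compounds. The entering group also stays within the scatter of the group in compound 2, with a 1.7-fold higher number from compound 2 to compound 4 (0.22 log units; within the scatter), while the contrast with 4-methoxyphenyl holds, with a 4.0-fold lower number from compound 1 to compound 4 (0.60 log units; beyond the scatter), so the three two-ring groups on this nitrogen now stand together and apart from compound 1. No supporting data bear on why the values fall this way.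

The compounds shown leave open whether an unsubstituted phenyl group on this nitrogen would fall with compound 1 or with the two-ring groups. Also open, as far as these compounds go, is whether an amine side chain on the two-ring group would move the number beyond the scatter.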